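Cyclohexyl for Methyl on the Amine of Compound 1

The source may report more compounds than this note shows. Statements on the series, on what has been measured and on what is new or still open speak of the compounds shown alone.

Of the compounds shown here, three sharing one core have been measured in an assay on isolated protein for binding affinity to adenosine receptor A1 (Bos taurus); on this read-out higher numbers stand for weaker inhibition and lower numbers for stronger inhibition. Compound 1 `CNc1nc(-c2ccccc2)nc2c1nnn2Cc1ccccc1Cl` gives 191000000 nM in this assay. Compound 2 `CNc1nc(-c2ccccc2)nc2c1nnn2Cc1ccccc1` gives 353000000 nM, and compound 3 `CNc1nc(-c2ccccc2)nc2c1nnn2Cc1ccccc1F` gives 25000000 nM. Compound 1 and compound 2 lie within the scatter of each other, a 1.8-fold higher number from compound 1 to compound 2 (0.27 log units; within the scatter), while compound 3 sits apart: a 7.6-fold lower number from compound 1 to compound 3 (0.88 log units; beyond the scatter) and a 14-fold lower number from compound 2 to compound 3 (1.15 log units; beyond the scatter). All three therefore bind only very weakly, and compound 1 stands among the two weaker-looking numbers.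

Compound 4 `Clc1ccccc1Cn1nnc2c(NC3CCCCC3)nc(-c3ccccc3)nc21` differs from compound 1 in one place: cyclohexyl in place of methyl on a nitrogen on an aromatic ring. The three measured steps all concern the substituent on the benzyl ring and leave the methylamino group untouched, so none of them speaks to this exchange. There is thus no measured ground for a direction, and any expectation rests on the change itself. The account expects the number for compound 4 to move downward from compound 1 by a 3.2-fold lower number from compound 1 to compound 4 (0.50 log units; beyond the scatter), with wide uncertainty. Compound 4 is estimated at 60000000 nM, with a range from 6000000 nM to 600000000 nM.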

Compound 4, inhibition constant: 34000000 nM
Estimate against measurement, compound 4: 1.8-fold (0.25 log units) above; the measured number falls inside the stated range.
By their numbers in this assay, from the lowest: compounds 3 and 4 (each within the scatter of the next); then compounds 1 and 2 (each within the scatter of the next).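

In this assay, for the compounds shown here, the amine substituent, which stayed methylamino throughout the earlier compounds, proves able to shift the number: cyclohexyl in place of methyl on a nitrogen on an aromatic ring gives a 5.6-fold lower number from compound 1 to compound 4 (0.75 log units; beyond the scatter), a step beyond the scatter. Going by these compounds alone, the first measured change at this position therefore moves the number downward, and the larger cyclohexyl group is tolerated without any loss in this read-out, although binding remains very weak. No available evidence bears on what lies behind this shift.

Going by these compounds, it remains open whether cyclopentyl, an open chain such as propyl, or a benzyl group on the same nitrogen would move the number in the same direction or as far. Also open, on these data alone, is whether the cyclohexylamino step would hold with hydrogen or fluoro in place of chloro on the benzyl ring.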